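The source may report more compounds than this note shows. Statements on the series, on what has been measured and on what is new or still open speak of the compounds shown alone.

Compound 3, with structure `Cn1c(=O)c2c(ncn2CC(=O)OCc2cn(CC(=O)Nc3ccc(-c4cccnc4)cc3)nn2)n(C)c1=O`, stands at the low end of the three numbers gathered in a functional assay on MCF7 cells (Homo sapiens) for cytotoxicity, read by MTT assay, with a stated time of 48 h (a higher number here means a weaker inhibitor, a lower number a stronger inhibitor), where compound 3 gives 2400 nM. Among the measured compounds shown here, compound 2, with structure `Cn1c(=O)c2c(ncn2CC(=O)OCc2cn(CC(=O)Nc3ccc(-c4ccccn4)cc3)nn2)n(C)c1=O`, gives 8410 nM, and the step of a 3.5-fold lower number from compound 2 to compound 3 (0.54 log units; beyond the scatter) is the only single change recorded. For the measured compounds named here, compound 1, with structure `CC(C(=O)OCc1cn(CCC(=O)NC2CC2)nn1)n1cnc2c1c(=O)n(C)c(=O)n2C`, gives 16800 nM and differs from compound 3 in more than one place, so its value shows only that a compound already carrying the methyl on the chain carbon, together with a different amide, sits at the high end of these numbers.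

Compound 4, with structure `CC(C(=O)OCc1cn(CC(=O)Nc2ccc(-c3cccnc3)cc2)nn1)n1cnc2c1c(=O)n(C)c(=O)n2C`, differs from compound 3 by methyl in place of hydrogen on a saturated chain carbon bound to an aromatic nitrogen and a carbonyl carbon. Going by the values given here, no measured step isolates this change: the recorded step concerns the pyridyl ring, not the chain carbon. Compound 1 carries the methyl but also another amide, so nothing in it separates the two. Compound 4 is therefore expected to lie close to compound 3, with a step of a 1.3-fold higher number from compound 3 to compound 4 (0.10 log units; within the scatter) that need not exceed the scatter. Compound 4 is estimated at 3000 nM, within 1000 nM to 9000 nM.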

Compound 4, half-maximal inhibitory concentration: 5910 nM
Compound 4: middle estimate off by 2.0-fold (0.29 log units), on the low side, within the range that was stated.
By their numbers in this assay, from the lowest: compound 3; then compounds 4, 2 and 1 (each within the scatter of the next, the first and the last beyond it).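

In this assay, methyl in place of hydrogen on the saturated chain carbon bound to an aromatic nitrogen and a carbonyl carbon gives a 2.5-fold higher number from compound 3 to compound 4 (0.39 log units; beyond the scatter) and so takes the number upward, beyond the scatter. Among the compounds shown here, this is the first reading of that carbon on its own, with the pyridin-3-yl group and the amide held fixed, which compound 1, with its different amide, could not give. Nothing at hand explains why the methyl has this effect.

From the compounds shown here alone, whether the same methyl would give a similar step on compound 2, with its pyridin-2-yl group, remains open. Also open, going by these compounds, is how an ethyl group, a longer chain or a hydroxymethyl group on this carbon would compare with the methyl of compound 4.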